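Piperazine nitrogen substitution in a Mer kinase series

The compounds below may be only part of what the source reports. "The series", "measured", "known", "first", "only" and "open" are said of these compounds alone.

Measured compounds:
compound 1, `CNc1ncc2c(-c3ccc(N4CCNCC4)nc3)nn(Cc3cn(-c4ccsc4C(=O)OC)nn3)c2n1`, 8900 nM
compound 2, `CNc1ncc2c(-c3ccc(N4CCN(C)CC4)nc3)nn(Cc3cn(Cc4ccccc4)nn3)c2n1`, 2000 nM

In an assay for inhibition of tyrosine-protein kinase Mer (Homo sapiens), read by 33P incorporation, in the presence of a further agent that is not named here (a lower number here means a stronger inhibitor, a higher number a weaker inhibitor), compound 1 gives 8900 nM. In this assay compound 2 gives 2000 nM, the lowest of the two numbers shown; compound 1 stands at a higher number, and the gap between them is beyond the scatter. The two compounds differ in more than one place, so the gap is not attributed to any single change.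

Compound 3, `CNc1ncc2c(-c3ccc(N4CCN(C(=O)C(C)(C)C)CC4)nc3)nn(Cc3cn(Cc4ccccc4)nn3)c2n1`, is not yet measured. It differs from compound 2 in one place: (tert-butyl)carbonyl in place of methyl on an amine nitrogen in a ring. Among the compounds with values here, no measured pair shows this kind of change, so no step size can be read from the data. Without such a reference the expectation is a small step toward a higher number, possibly none beyond the scatter, from compound 2 to compound 3: a 2.0-fold higher number from compound 2 to compound 3 (0.30 log units; within the scatter). Compound 3 is accordingly expected to give about 4000 nM, within a range of 1000 nM to 16000 nM.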

Compound 3, half-maximal inhibitory concentration: 5400 nM
The estimate for compound 3 lay 1.4-fold (0.13 log units) below the measured number; the measured number falls inside the stated range.
By their numbers in this assay, from the lowest: compound 2; then compounds 3 and 1 (each within the scatter of the next).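

In this assay, the only matched pair shown so far reads a 2.7-fold higher number from compound 2 to compound 3 (0.43 log units; beyond the scatter), for the change from 4-methylpiperazin-1-yl to 4-((tert-butyl)carbonyl)piperazin-1-yl. This gives the series its first reading at this amine nitrogen in a ring: the step is modest but beyond the scatter, and it runs against the larger group that brings in a carbonyl. Within the data shown here, with the rest of the molecule held constant, this position therefore responds to substitution, although one pair fixes only one step and no trend. No measurement in hand accounts for the size or direction of this step.

The pair changes the amine into a carbonyl-bearing group and enlarges the substituent at once, so it cannot say which of the two goes with the step; an acetyl group or a neopentyl group on the same nitrogen would begin to separate them. Compound 1 carries a hydrogen on this nitrogen but also differs elsewhere, so the same hydrogen on the rest of compound 2 would be needed to place the unsubstituted amine on this scale.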